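The source may report more compounds than this note shows. Statements on the series, on what has been measured and on what is new or still open speak of the compounds shown alone.

Measured so far in a functional assay on KOPN-8 cells (Homo sapiens) for antiproliferative activity, with a stated time of 72 h; on this read-out lower numbers stand for an effect already at smaller amounts and higher numbers for an effect only at larger amounts of compound:
- compound 1, `COC(=O)c1cc(=O)c2cc(N)ccc2[nH]1`: > 33700 nM
- compound 2, `COc1ccc(-c2cc(=O)c3c(OC)cc(OC)cc3n2S(=O)(=O)c2ccc(C)c([N+](=O)[O-])c2)cc1`: > 51700 nM

Compound 1 has the structure `COC(=O)c1cc(=O)c2cc(N)ccc2[nH]1` and in this assay gives only a limit, > 33700 nM. Compound 2 has the structure `COc1ccc(-c2cc(=O)c3c(OC)cc(OC)cc3n2S(=O)(=O)c2ccc(C)c([N+](=O)[O-])c2)cc1` and likewise gives only a limit, > 51700 nM. So compound 2 stands at a limit, with no number of its own; the one other value shown is a limit too (the limit of > 33700 nM in this assay, at which 1 of the 2 values shown sits, and (the limit of > 51700 nM in this assay, at which 1 of the 2 values shown sits)). Going by the values given here, no step between two measured compounds is available that would show how a change of this kind moves the read-out.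

Compound 3, `COc1ccc(-c2cc(=O)c3c(OC)cc(OC)cc3n2S(=O)(=O)c2ccc(Br)cc2)cc1`, has not yet been measured. It differs from compound 2 in one place: 4-bromophenyl in place of 4-methyl-3-nitrophenyl on a sulfonyl sulfur. Among the compounds with values here, with no measured step to lean on, the step is expected to be an at least 1.0-fold lower number from compound 2 to compound 3 (0.01 log units; that floor lies within the scatter), that is, none beyond the scatter. Compound 3 is therefore expected to give about 50000 nM, within a range from 15000 nM to 150000 nM, and most probably again only a limit.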

Compound 3, half-maximal effective concentration: > 86200 nM
Compound 3 was reported as a limit; the forecaster's own chance of this, stated with the estimate: 80%; middle value at least 1.7-fold (0.23 log units) away from the limit.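

Compound 2 and compound 3 each give only a limit in this assay, so the step from 4-methyl-3-nitrophenyl to 4-bromophenyl on the sulfonyl sulfur cannot be read. The compounds shown leave open which structural change, if any, would give an actual number rather than a limit in this assay.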